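The source may hold more compounds than are shown below. What is called first, only, known or untested is meant among the compounds shown, and "the series" means these compounds.

Compound 1 `OC12CCCC3CC(CCC31)C2` belongs to a small set of tricyclic saturated carbon frameworks examined in an ADME assay (Gallus gallus) for cytotoxicity, read by microscopy, with a stated time of 24 h; on this read-out higher numbers stand for lower toxicity in this test and lower numbers for higher toxicity in this test. In this assay compound 1 gives 6000000 nM, the highest of the two numbers recorded. Compound 3 `O[C@H]1C2CCCC3C[C@H]1CC[C@H]32` carries its hydroxy group differently on the same kind of core, and in this assay compound 3 gives 1800000 nM, a lower number lying beyond the usual scatter. Compound 2 `C1=C2CCCC3CC1CCC23`, the hydrocarbon without oxygen, has in this assay no result reported.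

Compound 4 `NC(=O)C12CCCC3CC(CCC31)C2` differs from compound 1 in one place: carbamoyl in place of hydroxy on a saturated ring carbon. Going by the values given here, no measured pair in this set shows such a change, so the step expected from compound 1 to compound 4 in this assay, a 1.5-fold lower number from compound 1 to compound 4 (0.18 log units; within the scatter), is taken as nothing beyond the scatter. Compound 4 is therefore estimated at 4000000 nM, within 1500000 nM to 10000000 nM.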

Compound 4, minimum cytotoxic concentration: 5200000 nM
Estimate against measurement, compound 4: 1.3-fold (0.11 log units) below, and the stated range covers the measured number.
By their numbers in this assay, from the lowest: compound 3; then compounds 4 and 1 (each within the scatter of the next).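

In this assay, carbamoyl in place of hydroxy on this saturated ring carbon gives a 1.2-fold lower number from compound 1 to compound 4 (0.06 log units; within the scatter), so compound 1 and compound 4 cannot be told apart. This first step between measured compounds differing in one place shows that, on this ring carbon, three heavy atoms can replace one without a shift beyond the scatter. Nothing available here bears on the reason for this result. Still open, as far as these compounds go, is whether an amine, a carboxylic acid or a longer chain on the same ring carbon would also stay within the scatter of compound 1.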